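Sulfonyl side chain cut back: cytotoxicity notes on compound 3

The source may hold more compounds than are shown below. What is called first, only, known or untested is meant among the compounds shown, and "the series" means these compounds.

Measured in an ADME assay on MDCK cells (Canis lupus familiaris) for cytotoxicity, with a stated time of 48 h (a lower number here means that less compound is tolerated, a higher number that more compound is tolerated), so far
compound 1 `CCC(CC)O[C@@H]1C=C([B-](F)(F)F)C[C@H](NC(=N)N)[C@H]1NC(C)=O` with "not determined" (no result reported)
compound 2 `CCC(CC)O[C@@H]1C=C(S(=O)(=O)CCc2ccncc2)C[C@H](NC(=N)N)[C@H]1NC(C)=O` with > 100000 nM

Compound 1 offers no number for comparison. In this assay compound 2 gives > 100000 nM as a limit of the assay, not a number.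

The next compound is compound 3 `CCC(CC)O[C@@H]1C=C(S(C)(=O)=O)C[C@H](NC(=N)N)[C@H]1NC(C)=O` and its change from compound 2 (hydrogen in place of (pyridin-4-yl)methyl on a saturated chain carbon bound to a sulfonyl sulfur) is hydrogen in place of (pyridin-4-yl)methyl on a saturated chain carbon bound to a sulfonyl sulfur. The same difference reads 2-(pyridin-4-yl)ethyl to methyl.

Among the measured compounds shown here, no step between measured compounds is available to size this change. For the measured compounds named here, compound 2 marks the limit of > 100000 nM in this assay, at which 1 of the 2 values shown sits, and is the only guide. The estimated step that the limit leaves unreadable from compound 2 to compound 3 is expected to stay within the scatter, with no favoured direction. In this assay the estimate for compound 3 is 120000 nM with an expected range from 60000 nM to 300000 nM and a report as a limit alone is likely.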

Compound 3, half-maximal cytotoxic concentration: > 100000 nM
Compound 3: no number, only a limit; the forecaster's own chance of this, stated with the estimate: 85%; the middle value does not contradict the limit.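

In this assay no step can be read from compound 2 to compound 3, as each compound is reported only as a limit of the assay: the limit of > 100000 nM in this assay, at which 2 of the 3 values shown sit.

The compounds shown leave open how far either compound lies from that limit, and whether 2-(pyridin-4-yl)ethyl to methyl changes the read-out at all.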